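Amide-to-urea switch on the shared core, dichlorophenyl variant

The source may hold more compounds than are shown below. What is called first, only, known or untested is meant among the compounds shown, and "the series" means these compounds.

Measured compounds in a functional assay on BT-549 cells (Homo sapiens) for inhibition, read by sulforhodamine B assay, with a stated time of 48 h; on this read-out lower numbers stand for stronger inhibition of growth and higher numbers for weaker inhibition of growth:
compound 1 `COc1cc(-c2nn(-c3cccc(NC(=O)c4cccc(C(F)(F)F)c4)c3)cc2-c2ccncc2)ccc1Cl` gives 2870 nM
compound 2 `COc1cc(-c2nn(-c3cccc(NC(=O)Nc4ccc(Cl)c(C(F)(F)F)c4)c3)cc2-c2ccncc2)ccc1Cl` gives 2360 nM
compound 3 `O=C(Nc1cccc(-n2cc(-c3ccncc3)c(-c3ccc(Cl)c(O)c3)n2)c1)Nc1ccc(Cl)c(C(F)(F)F)c1` gives 1250 nM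

Compound 1 carries the highest of the three numbers in this assay; compound 2 sits nearest, within the scatter, and compound 3 furthest, beyond it. Compound 4 `COc1cc(-c2nn(-c3cccc(NC(=O)Nc4ccc(Cl)c(Cl)c4)c3)cc2-c2ccncc2)ccc1Cl` is not yet measured. It differs from compound 1 in one place: (3,4-dichlorophenyl)amino in place of 3-(trifluoromethyl)phenyl on a carbonyl carbon.

Going by the values given here, the one measured step that bears on this change is the one from compound 1 to compound 2, where an arylamino group likewise replaced an aryl group on the carbonyl carbon: a 1.2-fold lower number from compound 1 to compound 2 (0.08 log units; within the scatter). Among the compounds with values here, compound 4 differs from compound 2 only in the substituents on the entering aryl ring, and no step between those two is available. The step from compound 2 to compound 3 concerns the methyl on the oxygen and does not inform this change.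

The expectation is therefore a step of no more than the scatter in this assay for compound 4, with the sign of the amide-to-urea step as a weak guide: a 1.2-fold lower number from compound 1 to compound 4 (0.08 log units; within the scatter). Compound 4 is estimated at 2400 nM, expected between 1200 nM and 4800 nM.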

Compound 4, concentration for 50% growth inhibition: 1680 nM
Compound 4: middle estimate off by 1.4-fold (0.15 log units), on the high side; measured number inside the range.
By their numbers in this assay, from the lowest: compounds 3, 4, 2 and 1 (each within the scatter of the next, the first and the last beyond it).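

In this assay a second arylamino group on the carbonyl carbon, now (3,4-dichlorophenyl)amino, gives a 1.7-fold lower number from compound 1 to compound 4 (0.23 log units; within the scatter) and so also stays within the scatter of the amide, as compound 2 did. Going by these compounds alone, the first change on the urea aryl ring, chloro in place of trifluoromethyl on an aromatic carbon, gives a 1.4-fold lower number from compound 2 to compound 4 (0.15 log units; within the scatter) and so does not separate the two ureas. Nothing measured here speaks to the reason for either step.

Open, going by these compounds, is whether an amine, a carboxylic acid or a longer chain on that aryl ring would move the number beyond the scatter. Within the data shown here, also open is whether hydrogen in place of methyl on the oxygen of compound 4 would give a step like the one between compound 2 and compound 3.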